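Shortening the alkyl chain on the purine imine

The source may report more compounds than this note shows. Statements on the series, on what has been measured and on what is new or still open speak of the compounds shown alone.

Measured so far:
compound 1 `Nc1n/c(=N\CCCCc2ccccc2)nc(N)c2c1ncn2Cc1ccccc1`: 18800 nM
compound 2 `CCCCCCCCCCCCCC/N=c1\nc(N)c2ncn(Cc3ccccc3)c2c(N)n1`: 6750 nM

In a functional assay on NCI-H460 cells (Homo sapiens) for antiproliferative activity, read by WST assay, with a stated time of 72 h (on this read-out higher numbers stand for weaker inhibition and lower numbers for stronger inhibition), compound 1 gives 18800 nM and compound 2 gives 6750 nM. Going by the values given here, compound 2 stands at the lowest number of the two, the only measured neighbour being compound 1, reached by the step of a 2.8-fold lower number from compound 1 to compound 2 (0.44 log units; beyond the scatter). Compound 3 `CCCCCCCCCC/N=c1\nc(N)c2ncn(Cc3ccccc3)c2c(N)n1` is not yet measured; it differs from compound 2 by hydrogen in place of butyl on a saturated chain carbon, ten or more bonds along the chain from a double-bonded nitrogen, so the long chain is kept but cut back.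

Among the compounds with values here, the one measured step that bears on this change is a 2.8-fold lower number from compound 1 to compound 2 (0.44 log units; beyond the scatter), which is modest and was produced by a larger change than the one now in question. Nothing in the two numbers tells whether chain length alone moves this assay. The expectation is therefore a step of about the scatter or somewhat beyond it, with a slightly higher number thought more likely as the chain moves back towards the shorter one of compound 1. For compound 3 in this assay the estimated step is a 1.4-fold higher number from compound 2 to compound 3 (0.15 log units; within the scatter), and the estimate for compound 3 is 9500 nM, within the range 4000 nM to 25000 nM.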

Compound 3, half-maximal inhibitory concentration: 3200 nM
Estimate against measurement, compound 3: 3.0-fold (0.47 log units) above; the whole stated range lies above it.
By their numbers in this assay, from the lowest: compound 3; then compound 2; then compound 1.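

In this assay, hydrogen in place of butyl on a saturated chain carbon, ten or more bonds along the chain from a double-bonded nitrogen, gives a 2.1-fold lower number from compound 2 to compound 3 (0.32 log units; beyond the scatter) and so shows that cutting back the long chain does not cost activity at this position, with the longer chain of compound 2 sitting at the higher number of the two. Set against the phenyl-bearing chain, the shorter alkyl chain gives a 5.9-fold lower number from compound 1 to compound 3 (0.77 log units; beyond the scatter) and places compound 3 lowest of the three, so the lower number of compound 2 relative to compound 1 does not reflect a simple gain from added chain. No measurement on hand accounts for either step.

As far as these compounds go, two saturated chains cannot fix an optimum length, and it remains open whether a chain shorter than that of compound 3, such as a hexyl or octyl chain, would lower the number further or raise it. Also open, from the compounds shown here alone, is how the series would respond to an amine or a carboxylic acid at the chain end, in place of the phenyl of compound 1.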